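The compounds below may be only part of what the source reports. "The series", "measured", "known", "first", "only" and "open" are said of these compounds alone.

Measured in an assay on membranes from liver for displacement of a labelled ligand from Sigma non-opioid intracellular receptor 1 (Rattus norvegicus); a higher number here means a weaker inhibitor, a lower number a stronger inhibitor:
compound 1 `O=c1oc2ccccc2n1CC1CCN(Cc2ccccc2)CC1` gives 3.6 nM
compound 2 `O=c1oc2ccccc2n1CC1CCN(Cc2ccc(Cl)cc2Cl)CC1` gives 258 nM

Among the measured compounds shown here, compound 1 holds the lowest number of the two in this assay; the only other point is compound 2, reached by a 72-fold higher number from compound 1 to compound 2 (1.86 log units; beyond the scatter). Compound 3 `Cc1cc(C)c(CN2CCC(Cn3c(=O)oc4ccccc43)CC2)c(C)c1` differs from compound 1 by 2,4,6-trimethylphenyl in place of phenyl on a saturated chain carbon bound to an amine nitrogen in a ring. For the measured compounds named here, the one measured step that bears on it is the same place carrying a different substituted phenyl, and that step was large. A weaker result is therefore expected for compound 3, though the size is uncertain, and the step is estimated as a 14-fold higher number from compound 1 to compound 3 (1.14 log units; beyond the scatter). Compound 3 is estimated at 50 nM, in a range from 6 nM to 400 nM.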

Compound 3, inhibition constant: 6230 nM
Compound 3: the middle estimate sits 120-fold (2.10 log units) below what was measured; the measured number lies above the stated range.
By their numbers in this assay, from the lowest: compound 1; then compound 2; then compound 3.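

In this assay, 2,4,6-trimethylphenyl on a saturated chain carbon bound to an amine nitrogen in a ring gives a 1700-fold higher number from compound 1 to compound 3 (3.24 log units; beyond the scatter), so both substituted phenyls shown fall well short of phenyl. The two substituted groups also separate, with 2,4,6-trimethylphenyl in place of 2,4-dichlorophenyl giving a 24-fold higher number from compound 2 to compound 3 (1.38 log units; beyond the scatter), so the outcome at this position depends on which substituted phenyl is present. Nothing available explains this gap.

From the compounds shown here alone, whether the number of substituents or their kind sets the size of the step remains open. A single methyl or single chlorine on the phenyl would help separate the two.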